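One more double bond in a long side chain

The source may report more compounds than this note shows. Statements on the series, on what has been measured and on what is new or still open speak of the compounds shown alone.

Measured in a functional assay on MDA-MB-231 cells (Homo sapiens) for antiproliferative activity, read by MTT assay (on this read-out lower numbers stand for stronger inhibition and higher numbers for weaker inhibition), so far:
- compound 1 (`CCCC/C=C\CCCCCCCCCc1cc(=O)c2c(O)c(C)c(OCOC)cc2o1`) gives > 87000 nM (a limit, not a number)
- compound 2 (`CCCCC/C=C\C/C=C\CCCCCCCC1(O)CC(=O)c2c(O)c(C)c(O)c(C)c2O1`) gives 42800 nM

Compound 1 is reported only as a limit (> 87000 nM). For the measured compounds named here, compound 2 carries the only exact number so far (42800 nM), so nothing exact yet exists to rank it against. Compound 3 (`CC/C=C\C/C=C\C/C=C\CCCCCCCC1(O)CC(=O)c2c(O)c(C)c(O)c(C)c2O1`) keeps the core of compound 2 and alters only the long chain. The change (but-1-en-1-yl in place of butyl on a saturated chain carbon bound to a double-bonded chain carbon) is but-1-en-1-yl in place of butyl on a saturated chain carbon bound to a double-bonded chain carbon. Going by the values given here, no measured pair shows what such a change does, so no step beyond the scatter is expected in this assay. The estimate therefore starts from compound 2 (42800 nM). The expected change is a 1.1-fold lower number from compound 2 to compound 3 (0.05 log units; within the scatter). Compound 3 is estimated at 38000 nM, with an expected range from 15000 nM to 85000 nM.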

Compound 3, half-maximal inhibitory concentration: 42800 nM
Beside the measured number, compound 3's estimate is 1.1-fold (0.05 log units) below it; the range from low to high includes it.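

In this assay, for the compounds shown here, this is the first pair of compounds that differ in one place, and putting but-1-en-1-yl in place of butyl on a saturated chain carbon bound to a double-bonded chain carbon gives no change at the digits printed from compound 2 to compound 3 (within the scatter). At this place in the long chain, then, one more double bond leaves the read-out where it was, which no earlier comparison could show. Compound 1 stands only as a limit, not a number: the limit of > 87000 nM in this assay, at which 1 of the 3 values shown sits.

From the compounds shown here alone, whether a much shorter chain, or a carboxylic acid or an amine on the long chain, would move the number beyond the scatter remains open. A single pair also cannot say whether the same change would read the same way on a different core.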